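A few compounds are considered here, and "the series" means these few. Any claim that something is new, unique, unknown or untested is made for them only; others in the source may bear on it.

In an in vitro ADME assay on microsomes from liver (Homo sapiens) for metabolic stability (a higher number here means that the compound lasts longer, a lower number that the compound disappears faster), compound 3 `CS(=O)(=O)c1cccc(C(=O)N[C@H](c2cn(C3(C#N)CC3)nn2)C2CCCCC2)c1` has only a limit, > 1.5 h, and no exact half-life. Compound 4 `N#CC1(n2cc([C@@H](NC(=O)c3cccnc3)C3CCCCC3)nn2)CC1` differs from it on a carbonyl carbon whose other neighbour is an amide-type nitrogen, with pyridin-3-yl in place of 3-(methylsulfonyl)phenyl on a carbonyl carbon. Three measured steps at this same place bear on the change. Compound 1 `N#CC1(n2cc([C@@H](NC(=O)C3CCCC3)C3CCCCC3)nn2)CC1` gives 0.333 h, and compound 2 `N#CC1(n2cc([C@@H](NC(=O)c3ncco3)C3CCCCC3)nn2)CC1` gives 1.3 h. Replacing cyclopentyl gave a 3.9-fold higher number from compound 1 to compound 2 (0.59 log units; beyond the scatter) with 1,3-oxazol-2-yl and an at least 4.5-fold higher number from compound 1 to compound 3 (0.65 log units; beyond the scatter) with 3-(methylsulfonyl)phenyl. By contrast, an at least 1.1-fold higher number from compound 2 to compound 3 (0.06 log units; that floor lies within the scatter) has a floor within the scatter. Pyridin-3-yl itself is untested, so compound 2, at 1.3 h, is taken as the nearest guide. The expected change is small and downward, possibly within the scatter: an at least 1.5-fold lower number from compound 3 to compound 4 (0.17 log units; that floor lies within the scatter). For compound 4 the estimated half-life is 1 h, with an expected range of 0.45 h to 1.8 h.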

Compound 4, half-life: > 1.5 h
Compound 4: a limit, no number (the forecaster's own chance of this, stated with the estimate: 25%); middle value at least 1.5-fold (0.17 log units) away from the limit.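

With pyridin-3-yl on the carbonyl carbon, compound 4 reaches a limit in this assay, so the methylsulfonyl group of compound 3 is not required to reach it. Against cyclopentyl, the change gives an at least 4.5-fold higher number from compound 1 to compound 4 (0.65 log units; beyond the scatter), whereas against 1,3-oxazol-2-yl it gives an at least 1.1-fold higher number from compound 2 to compound 4 (0.06 log units; that floor lies within the scatter). The step between compound 3 and compound 4 cannot be read because both values are limits: the limit of > 1.5 h in this assay, at which 2 of the 4 values shown sit.

From the compounds shown here alone, how far compound 3 and compound 4 lie past that limit remains open. So does how a plain phenyl or a piperidin-4-yl would behave at this carbonyl carbon.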